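The source may report more compounds than this note shows. Statements on the series, on what has been measured and on what is new or still open speak of the compounds shown alone.

Compound 1, `CCOC(=O)c1oc2ccc(NS(=O)(=O)c3ccc(Cl)cc3)cc2c1C`, is the reference here; in a functional assay on MCF7 cells (Homo sapiens) for antiproliferative activity, read by MTT assay, with a stated time of 72 h (a lower number here means a stronger inhibitor, a higher number a weaker inhibitor), compound 1 gives 81200 nM. Compound 2, `CCOC(=O)c1oc2ccc(NS(=O)(=O)c3cccc(Cl)c3)cc2c1C`, differs from it in the core by 3-chlorophenyl in place of 4-chlorophenyl on a sulfonyl sulfur, and in this assay compound 2 gives 83900 nM, a 1.0-fold higher number from compound 1 to compound 2 (0.01 log units; within the scatter). Compound 3, `CCOC(=O)c1oc2ccc(NS(=O)(=O)c3ccc(C(F)(F)F)cc3)cc2c1C`, carries trifluoromethyl in place of chloro on an aromatic carbon; in this assay compound 3 gives 48700 nM, a 1.7-fold lower number from compound 1 to compound 3 (0.22 log units; within the scatter). The not yet measured compound 4, `CCOC(=O)c1oc2ccc(NS(=O)(=O)c3cccc(C(F)(F)F)c3)cc2c1C`, arises from compound 2 by trifluoromethyl in place of chloro on an aromatic carbon. This is the same kind of change as that from compound 1 to compound 3, but the place differs: there the group stands para to a large group, here meta to a large group. The step is expected to be a 1.7-fold lower number from compound 2 to compound 4 (0.22 log units; within the scatter), resting on a 1.7-fold lower number from compound 1 to compound 3 (0.22 log units; within the scatter). Compound 4 is therefore estimated at 50000 nM, between 25000 nM and 100000 nM.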

Compound 4, half-maximal inhibitory concentration: 51400 nM
Compound 4: the middle estimate sits 1.0-fold (0.01 log units) below what was measured; low and high end bracket the measured number.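

In this assay, trifluoromethyl in place of chloro gives a 1.6-fold lower number from compound 2 to compound 4 (0.21 log units; within the scatter), and this step agrees with the one seen on the other core: the same change on two cores in this assay, a 1.7-fold lower number (0.22 log units; within the scatter) from compound 1 to compound 3 and a 1.6-fold lower number (0.21 log units; within the scatter) from compound 2 to compound 4, 1.0-fold (0.01 log units) apart, within the scatter of two such steps The change therefore carries over between these two cores with much the same size, whether the group stands on the ring of compound 1 or of compound 2. This does not show that the change itself has a real effect, since each step lies within the scatter, and two pairs in one assay say nothing about cores beyond these.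

The compounds shown leave open whether other groups on this aromatic ring, such as an amine or a methoxy group, would give a clearer step. They also leave open what a carboxylic acid in place of the ethyl ester would do.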